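The compounds below may be only part of what the source reports. "The series", "measured", "known", "first", "only" and "open" are said of these compounds alone.

In a functional assay on A549 cells (Homo sapiens) for inhibition, read by colorimetric assay and MTT assay, with a stated time of 72 h (on this read-out lower numbers stand for stronger inhibition and higher numbers for weaker inhibition), compound 1 (`COc1ccc2c(c1)-c1cnc(n1C)OCCCCCCCCO2`) gives 40000 nM and compound 2 (`C=CCCCCOc1ccc(OC)cc1-c1cnc(OCCC=C)n1C`) gives 43000 nM, while compound 3 (`C=CCCCCCOc1ncc(-c2ccccc2OCCCCC=C)n1C`) gives 62000 nM and so stands within the usual scatter of both others. Compound 4 (`C=CCCCCOc1ccccc1-c1cnc(S(=O)(=O)c2ccccc2)n1C`) is still unmeasured. It has phenylsulfonyl in place of (hept-6-en-1-yl)oxy on an aromatic carbon. Going by the values given here, no measured compound carries phenylsulfonyl, so the data offer no direct guide. Compound 1 at 40000 nM and compound 3 at 62000 nM differ in their chains yet lie within the scatter, so no step beyond it is expected here, only an estimated 1.8-fold lower number from compound 3 to compound 4 (0.25 log units; within the scatter) toward a lower number. For compound 4 the estimated value is 35000 nM within a range from 12000 nM to 90000 nM in this assay for now.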

Compound 4, half-maximal inhibitory concentration: 38000 nM
Compound 4: the middle estimate sits 1.1-fold (0.04 log units) below what was measured, within the range that was stated.
By their numbers in this assay, from the lowest: compounds 4, 1, 2 and 3 (each within the scatter of the next).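

In this assay, phenylsulfonyl on the aromatic carbon between two ring nitrogen atoms, in place of (hept-6-en-1-yl)oxy, gives a 1.6-fold lower number from compound 3 to compound 4 (0.21 log units; within the scatter). This position therefore takes a group with an aromatic ring instead of a chain with no ring, and the number stays within the scatter. Nothing measured bears on why this step is so small. On these data alone, whether an amine or a carboxylic acid at this position would give a step beyond the scatter stays open, and the same holds for a much shorter alkoxy chain.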